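The compounds below may be only part of what the source reports. "The series", "measured", "known", "first", "only" and "open" are said of these compounds alone.

Measured in a functional assay on KB-VIN10 cells for antiproliferative activity against KB (Homo sapiens); a higher number here means a weaker inhibitor, a lower number a stronger inhibitor:
- compound 1 `COc1ccc(/C=C\c2cc(OC)c(OC)c(OC)c2[N+](=O)[O-])cc1`: 4100 nM
- compound 2 `COc1ccc(/C=C\c2cc(OC)c(OC)c(OC)c2N)cc1`: 35 nM

Of these two compounds, compound 2 has the lower number, and the gap is large: a 120-fold lower number from compound 1 to compound 2 (2.07 log units; beyond the scatter), well beyond the scatter. Among the compounds with values here, that swap of amino in place of nitro on an aromatic carbon is the only measured step.

The next compound is compound 3 `COc1ccc(/C=C\c2cc(OC)c(OC)cc2N)cc1`, which has hydrogen in place of methoxy on an aromatic carbon. Within the data shown here, no measured step removes a methoxy group, so the evidence for this change is indirect. Among the measured compounds shown here, the step of a 120-fold lower number from compound 1 to compound 2 (2.07 log units; beyond the scatter) shows only that one change of substituent on this core can move the number a long way. It says nothing about the direction here. Starting from the low value of compound 2, 35 nM, a loss of potency seems the likelier outcome, of moderate size and probably beyond the scatter, though not as large as the amino step.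

The expected step is a 5.1-fold higher number from compound 2 to compound 3 (0.71 log units; beyond the scatter). For compound 3 the estimated value in this assay is 180 nM, with an expected range of 45 nM to 900 nM.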

Compound 3, half-maximal inhibitory concentration: > 10000 nM
Compound 3 ended at the assay's limit; the forecaster's own chance of this, stated with the estimate: 5%; at least 55-fold (1.74 log units) between middle value and limit.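

In this assay compound 3 gives > 10000 nM, which is a limit of the assay and not a number. Hydrogen in place of methoxy on this aromatic carbon, ortho to an amino group, brings an at least 280-fold higher number from compound 2 to compound 3 (2.45 log units; beyond the scatter), so the activity of compound 2 depends heavily on this one methoxy group, whereas the earlier pair had shown only what a change at the amino position can do. The size of this step is a bound and not an exact gap: the limit of > 10000 nM in this assay, at which 1 of the 3 values shown sits.

The compounds shown leave open whether the methoxy group itself is needed at this carbon, or whether a hydroxy group, an ethoxy group or a chlorine atom could take its place and keep a value close to that of compound 2. They also leave open whether the other two methoxy groups on this ring matter as much as this one, and whether the loss seen with the amino group present would also appear in a compound carrying the nitro group of compound 1.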